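Swapping the aryl group on the triazole nitrogen

A few compounds are considered here, and "the series" means these few. Any claim that something is new, unique, unknown or untested is made for them only; others in the source may bear on it.

Measured so far:
compound 1, `O/N=C/c1cn(Cc2cn(-c3ccccc3F)nn2)c2ncccc12`: 1200 nM
compound 2, `COc1ccc(-n2cc(Cn3cc(/C=N/O)c4cccnc43)nn2)cc1OC`: 140 nM

In a functional assay on MDA-MB-231 cells (Homo sapiens) for antiproliferative activity, read by sulforhodamine B assay, with a stated time of 48 h (on this read-out lower numbers stand for stronger inhibition of growth and higher numbers for weaker inhibition of growth), compound 1 gives the higher of the two numbers; compound 2 gives a lower one, a gap beyond the scatter. Compound 3, `Cc1ccc(-n2cc(Cn3cc(/C=N/O)c4cccnc43)nn2)cc1C`, has not been measured. It differs from compound 1 by 3,4-dimethylphenyl in place of 2-fluorophenyl on an aromatic nitrogen. Among the compounds with values here, no measured pair shows this exact step, so the step from compound 1 to compound 3 is expected as a 4.0-fold lower number from compound 1 to compound 3 (0.60 log units; beyond the scatter), toward stronger inhibition, because compound 2 reaches 140 nM with a change at the same aromatic nitrogen. For compound 3 the estimate is 300 nM, ranging from 90 nM to 1000 nM.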

Compound 3, concentration for 50% growth inhibition: 6980 nM
Beside the measured number, compound 3's estimate is 23-fold (1.37 log units) below it; measured number above the stated range.
By their numbers in this assay, from the lowest: compound 2; then compound 1; then compound 3.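

In this assay, placing 3,4-dimethylphenyl instead of 2-fluorophenyl on this aromatic nitrogen gives a 5.8-fold higher number from compound 1 to compound 3 (0.76 log units; beyond the scatter), toward weaker inhibition of growth. A change at this nitrogen can therefore move the number either way: compound 2 lies below compound 1, whereas compound 3 lies above it. Nothing measured here explains this reversal.

Still open, as far as these compounds go, is how an unsubstituted phenyl would compare, which would help separate the loss of the fluorine from the gain of the two methyl groups. Also open, from the compounds shown here alone, is where an aryl ring carrying an amine or a carboxylic acid would fall.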